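Heteroaryl exchange on the chlorophenyl arm of compound 2

The source may report more compounds than this note shows. Statements on the series, on what has been measured and on what is new or still open speak of the compounds shown alone.

For the measured compounds named here, compound 2 `Cn1nc2c(=O)n(CC3(O)CCN(Cc4ccc(-c5cncs5)cc4Cl)CC3)cnc2c1-c1ccc(CN)cc1` gives 117 nM in an assay on isolated protein for inhibition of ubiquitin carboxyl-terminal hydrolase 7 (Homo sapiens), with stated times of 30 min and 2 h (on this read-out higher numbers stand for weaker inhibition and lower numbers for stronger inhibition), which places it second highest of the three numbers measured so far. Compound 3 `CCCNCc1ccc(-c2c3ncn(CC4(O)CCN(Cc5ccc(-c6ccco6)cc5Cl)CC4)c(=O)c3nn2C)cc1` sits nearest, and in this assay compound 3 gives 43.9 nM; compound 1 `Cn1nc2c(=O)n(CC3(O)CCN(Cc4ccc(-c5ccco5)cc4Cl)CC3)cnc2c1-c1ccc(C(F)(F)F)cc1` is furthest, and in this assay compound 1 gives 530 nM. Compound 4 `Cn1nc2c(=O)n(CC3(O)CCN(Cc4ccc(-n5ccnc5)cc4Cl)CC3)cnc2c1-c1ccc(CN)cc1` is not yet measured; it differs from compound 2 by 1H-imidazol-1-yl in place of 1,3-thiazol-5-yl on an aromatic carbon.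

Going by the values given here, the only step measured in a single place, a 12-fold lower number from compound 1 to compound 3 (1.08 log units; beyond the scatter), concerns the trifluoromethyl to (propylamino)methyl exchange at a different site, so it does not bear on the present change. Among the compounds with values here, compound 1 and compound 2 differ in two places, so their values show only that compound 1 gives the higher number. Within the data shown here, no measured step tests the swap of one five-membered aromatic ring with two hetero atoms for another. In this assay the step from compound 2 to compound 4 is therefore expected to be a 1.0-fold higher number from compound 2 to compound 4 (0.01 log units; within the scatter), none beyond the scatter. Compound 4 is estimated at 120 nM, with a range from 45 nM to 320 nM.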

Compound 4, half-maximal inhibitory concentration: 228 nM
For compound 4 the middle estimate is 1.9-fold (0.28 log units) below the measured one, within the range that was stated.
By their numbers in this assay, from the lowest: compound 3; then compounds 2 and 4 (each within the scatter of the next); then compound 1.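

In this assay, 1H-imidazol-1-yl in place of 1,3-thiazol-5-yl on the aromatic carbon para to a large group gives a 1.9-fold higher number from compound 2 to compound 4 (0.29 log units; within the scatter), the only single-place reading at this position among the compounds shown. Between these two five-membered aromatic rings with 2 hetero atoms, then, a ring joined through nitrogen and lacking sulfur gives a step that stays within the scatter, with the rest of the structure unchanged. Nothing measured here speaks to the origin of this step.

The furan ring of compound 1 and compound 3 cannot be read against these two, as both compounds also differ elsewhere. Still open, as far as these compounds go, is how a six-membered pyridine ring, a saturated morpholine ring or a carboxylic acid would read at this position.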